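Three Compounds at the Cytotoxicity Limit, a Fourth Expected

The source may report more compounds than this note shows. Statements on the series, on what has been measured and on what is new or still open speak of the compounds shown alone.

Compound 1 `N#Cc1ccc2c(c1)S(=O)(=O)C=C(c1c(O)c3cc(F)ccc3n(Cc3ccc(F)cc3)c1=O)N2`: in an ADME assay on 2209-23 cells (Homo sapiens) for cytotoxicity, read by WST assay (a higher number here means that more compound is tolerated, a lower number that less compound is tolerated), compound 1 gives > 50000 nM, which is a limit of the measurement.
Compound 2 `CS(=O)(=O)Nc1ccc2c(c1)S(=O)(=O)C=C(c1c(O)c3c(Cl)cccc3n(Cc3ccc(F)cc3)c1=O)N2`: in this assay compound 2 gives > 50000 nM, again a limit.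
Compound 3 `CS(=O)(=O)Nc1ccc2c(c1)S(=O)(=O)C=C(c1c(O)c3cc(F)ccc3n(Cc3ccc(F)c(Cl)c3)c1=O)N2`: in this assay compound 3 gives > 50000 nM, also a limit.

Compound 3 therefore stands nowhere in particular on the numbers shown: its value is a limit, and the two other values are limits as well, so the three compounds cannot be told apart in this assay, as the limit of > 50000 nM in this assay, at which 3 of the 3 values shown sit, states. Going by the values given here, no step between measured compounds can be drawn from these limits.

Compound 4 `CCCC(C)n1c(=O)c(C2=CS(=O)(=O)c3cc(NS(C)(=O)=O)ccc3N2)c(O)c2cc(F)ccc21` differs from compound 3 in one place: 1-methylbutyl in place of 3-chloro-4-fluorobenzyl on an aromatic nitrogen. With every measured value sitting at the limit, no direction and no size of step beyond the scatter is indicated for this change; the expectation is simply that compound 4 also reaches the limit, and the step from compound 3 to compound 4 is estimated as a step that the limit leaves unreadable from compound 3 to compound 4. Compound 4 is estimated at 60000 nM, with a range from 25000 nM to 150000 nM.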

Compound 4, half-maximal cytotoxic concentration: > 50000 nM
Compound 4: only a limit was reported; the forecaster's own chance of this, stated with the estimate: 80%; the middle value lies beyond the limit too.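

No step can be read from compound 3 to compound 4, since both values are limits: the limit of > 50000 nM in this assay, at which 4 of the 4 values shown sit.

The compounds shown leave open how far past that limit each one lies, and whether 1-methylbutyl in place of 3-chloro-4-fluorobenzyl changes cytotoxicity at all.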